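The compounds below may be only part of what the source reports. "The series", "measured", "known", "first", "only" and "open" are said of these compounds alone.

Measured so far:
compound 1, `C=C1[C@H](C)CCC[C@]1(C)CC/C(C)=C/CC1=C(O)C(=O)C=C(N[C@@H](C(=O)O)[C@@H](C)O)C1=O`: in an ADME assay on L1210 cells (Mus musculus) for cytotoxicity, with a stated time of 48 h (on this read-out lower numbers stand for stronger inhibition and higher numbers for weaker inhibition), compound 1 gives > 10 ug/mL, a limit of the assay rather than a number.
compound 2, `CC1=CCC[C@](C)(CC/C(C)=C/CC2=C(O)C(=O)C=C(N[C@@H](CO)C(=O)O)C2=O)[C@@H]1C`: in this assay compound 2 gives > 10 ug/mL, likewise a limit of the assay and not a number.

Among the measured compounds shown here, compound 2 therefore stands only at the limit of > 10 ug/mL in this assay, at which 2 of the 2 values shown sit, with no number of its own and no measured step to any other compound. Compound 3, `CC1=CCC[C@](C)(CC/C(C)=C/CC2=C(O)C(=O)C=C(N[C@H](C(=O)O)[C@@H](C)O)C2=O)[C@@H]1C`, differs from compound 2 by methyl in place of hydrogen on a saturated chain carbon bound to an oxygen on a saturated carbon and a saturated chain carbon. For the measured compounds named here, with no step between measured compounds in this assay, there is no measured size of step to draw on, and a change of this kind is expected to give none beyond the scatter. The expected step is a step that the limit leaves unreadable from compound 2 to compound 3, none beyond the scatter. Compound 3 is estimated at 15 ug/mL, with a range from 5 ug/mL to 40 ug/mL, and a limit is again the likeliest outcome.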

Compound 3, half-maximal inhibitory concentration: > 10 ug/mL
Compound 3 was reported as a limit; the forecaster's own chance of this, stated with the estimate: 75%; the middle value does not contradict the limit.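

No step can be read between compound 2 and compound 3, as both results are limits of the assay and not numbers: the limit of > 10 ug/mL in this assay, at which 3 of the 3 values shown sit.

The compounds shown leave open what number any of them would reach in this assay, and whether methyl in place of hydrogen at this place changes it.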